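The source may report more compounds than this note shows. Statements on the series, on what has been measured and on what is new or still open speak of the compounds shown alone.

Compound 2 `Cc1c(O)ccc2c1[C@H](Cn1cc(-c3ccc(C(F)(F)F)cc3)nn1)[C@@]13CC(=O)[C@@](C)(CC[C@@H]21)C3` bears a trifluoromethyl on its outer aromatic ring. In a functional assay on HL-60 cells (Homo sapiens) for cytotoxicity, read by MTT assay, with a stated time of 4 days (on this read-out lower numbers stand for stronger inhibition and higher numbers for weaker inhibition), compound 2 yields only a limit of the assay, > 20000 nM. On the numbers shown, compound 2 thus stands at the edge of the measured range, and the one other value shown is a limit as well. That other value belongs to compound 1 `Cc1c(O)ccc2c1[C@H](Cn1cc(-c3ccc(F)cc3)nn1)[C@@]13CC(=O)[C@@](C)(CC[C@@H]21)C3`, which differs from compound 2 only by fluoro in place of trifluoromethyl. In this assay compound 1 also gives only a limit, > 20000 nM. The step that the two limits leave unreadable from compound 1 to compound 2 is accordingly of unknown size, both of its ends sitting at the limit of > 20000 nM in this assay, at which 2 of the 2 values shown sit. Compound 3 `Cc1ccc(-c2cn(C[C@H]3c4c(ccc(O)c4C)[C@@H]4CC[C@@]5(C)C[C@]43CC5=O)nn2)cc1` is not yet measured; its change from compound 2 is methyl in place of trifluoromethyl on an aromatic carbon, which read one bond further out is 4-(trifluoromethyl)phenyl to 4-methylphenyl. Going by the values given here, only the step from compound 1 to compound 2 bears on this change, and its size cannot be read from two limits. One therefore expects no movement beyond the scatter, and compound 3 is expected again at the limit, an estimated step that the limit leaves unreadable from compound 2 to compound 3. The estimate for compound 3 in this assay is 35000 nM, with a range from 10000 nM to 120000 nM.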

Compound 3, half-maximal inhibitory concentration: > 20000 nM
Compound 3 gave a limit, no number; the forecaster's own chance of this, stated with the estimate: 85%; the middle value does not contradict the limit.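

Compound 3, like compound 1 and compound 2, gives only a limit in this assay, so no step among these three compounds can be read: the limit of > 20000 nM in this assay, at which 3 of the 3 values shown sit.

The compounds shown leave open whether exchanging fluoro, trifluoromethyl and methyl changes the read-out at all, since none of the three has a measured number.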